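The source may report more compounds than this note shows. Statements on the series, on what has been measured and on what is new or still open speak of the compounds shown alone.

Compound 3 `O=C(CCl)Nc1ccc(S(=O)(=O)Oc2ccccc2I)cc1` gives 2500 nM in a functional assay on MCF7 cells (Homo sapiens) for antiproliferative activity, read by sulforhodamine B assay, with a stated time of 48 h (a higher number here means a weaker inhibitor, a lower number a stronger inhibitor), the lowest of the three numbers recorded so far. Compound 2 `CC(C)c1ccccc1OS(=O)(=O)c1ccc(NC(=O)CCl)cc1` gives 2900 nM in this assay, and a 1.2-fold lower number from compound 2 to compound 3 (0.06 log units; within the scatter). Compound 1 `CC(=O)Nc1cccc(S(=O)(=O)Oc2ccccc2C(C)C)c1` gives 21000 nM in this assay, well apart from compound 3. Compound 4 `CCCNC(=O)Nc1ccc(S(=O)(=O)Oc2ccccc2I)cc1` differs from compound 3 by propylamino in place of chloromethyl on a carbonyl carbon. Among the compounds with values here, no measured step touches the group on the carbonyl carbon; the single measured step, from compound 2 to compound 3, concerns the aromatic substituent and was small. Compound 1, which carries no chloromethyl, shows a far higher number than compound 2 and compound 3, although it differs from them elsewhere too. Compound 4 is expected to give a higher number, with a 6.0-fold higher number from compound 3 to compound 4 (0.78 log units; beyond the scatter), estimated at 15000 nM within a range from 4000 nM to 50000 nM.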

Compound 4, half-maximal inhibitory concentration: 2900 nM
Compound 4: the middle estimate sits 5.2-fold (0.71 log units) above what was measured; the measured number lies below the stated range.
By their numbers in this assay, from the lowest: compounds 3, 2 and 4 (each within the scatter of the next); then compound 1.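

In this assay, within the data shown here, the first measured step at this carbonyl carbon stays within the scatter, with a 1.2-fold higher number from compound 3 to compound 4 (0.06 log units; within the scatter). Compound 3 and compound 4 thus cannot be told apart, so on this core the chloromethyl group is not required for a number of this size: propylamino, which is larger and carries a hydrogen-bond donor, serves equally well. No available evidence accounts for the two groups reading alike. Still open, going by these compounds, is whether a carboxylic acid, a cyclic amine or a longer chain on this carbonyl carbon would read the same, and whether propylamino would also match chloromethyl with isopropyl on the aromatic carbon in place of iodo.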